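The source may report more compounds than this note shows. Statements on the series, on what has been measured and on what is new or still open speak of the compounds shown alone.

The study reads cytotoxicity in a functional assay on B16 cells (Mus musculus) for cytotoxicity, read by MTT assay, with a stated time of 48 h; on this read-out higher numbers stand for weaker inhibition and lower numbers for stronger inhibition. Going by the values given here, compound 1 `CC1(C)OC[C@H](Cn2cc(-c3ccc([N+](=O)[O-])cc3)nn2)O1` is the first member. In this assay compound 1 reaches only a limit, > 100000 nM. Among the compounds with values here, compound 2 `CC1(C)OCC(Cn2cc(-c3ccc(C(F)(F)F)cc3)nn2)O1`, which shares the 2,2-dimethyl-1,3-dioxolan-4-yl group of compound 1, is the one member with a number: in this assay compound 2 gives 13500 nM. Compound 3 `CCOC(=O)Cn1cc(-c2ccc3ccccc3c2)nn1` carries an ethoxycarbonyl chain instead. In this assay compound 3 is recorded only as a limit, > 100000 nM. Compound 3 therefore sits at the limit of > 100000 nM in this assay, at which 2 of the 3 values shown sit, and its distance from compound 2 cannot be read as a number.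

The step to compound 4 `CC1(C)OC[C@H](Cn2cc(-c3ccc4ccccc4c3)nn2)O1` is 2,2-dimethyl-1,3-dioxolan-4-yl in place of ethoxycarbonyl on a saturated chain carbon bound to an aromatic nitrogen; compound 4 keeps the aryl portion of compound 3 and takes on the 2,2-dimethyl-1,3-dioxolan-4-yl group found in compound 1 and compound 2. Within the data shown here, no pair of measured compounds shows this exchange on its own, so its size is unknown. Among the measured compounds shown here, the only guide is that the dioxolane-bearing pair contains a measurable value, that of compound 2 at 13500 nM. Compound 4 is expected to move toward a measurable number without becoming potent, with an estimated step of an at least 2.5-fold lower number from compound 3 to compound 4 (0.39 log units; beyond the scatter). Compound 4 is thus estimated at 40000 nM, within a range of 10000 nM to 100000 nM.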

Compound 4, half-maximal inhibitory concentration: 12000 nM
Compound 4: the middle estimate sits 3.3-fold (0.52 log units) above what was measured, within the range that was stated.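

Going by these compounds alone, with the aryl portion of compound 3 held fixed, placing 2,2-dimethyl-1,3-dioxolan-4-yl in place of ethoxycarbonyl on a saturated chain carbon bound to an aromatic nitrogen gives an at least 8.3-fold lower number from compound 3 to compound 4 (0.92 log units; beyond the scatter) in this assay, so the first direct reading of this exchange shows that the group at this position can decide whether a measurable number appears at all. That step gives only a minimum size, because the value of compound 3 is a limit of the assay and not a number: the limit of > 100000 nM in this assay, at which 2 of the 4 values shown sit. The dioxolane group does not secure a measurable number on its own, since compound 1 carries it and is recorded only as a limit, > 100000 nM, so the aryl portion matters as well.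

Going by these compounds, how far the number would move with a carboxylic acid, a primary amide or an open-chain diol at this place remains open, and so does the true size of the exchange, which a number for compound 3 would be needed to fix. The compounds shown also leave open whether the opposite configuration at the stereocentre of the 2,2-dimethyl-1,3-dioxolan-4-yl group would change the value of compound 4.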